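Swapping the para substituent on the aryl ketone: hydroxy to chloro

This account rests on a few compounds, and the source may have more. Where it says the series, first, only, none or still open, it means among the compounds named here.

Compound 1 `COc1ccc(C(=O)/C=C/c2cc3ccccc3[nH]c2=O)cc1` — 7590 nM
Compound 2 `O=C(/C=C/c1cc2ccccc2[nH]c1=O)c1ccc(O)cc1` — 5110 nM

Of the compounds shown here, two sharing one core have been measured in a functional assay on SK-MEL-28 cells (Homo sapiens) for cytotoxicity, read by sulforhodamine B assay, with a stated time of 24 h; on this read-out higher numbers stand for weaker inhibition of growth and lower numbers for stronger inhibition of growth. Compound 1 gives 7590 nM, and compound 2 gives 5110 nM. For the measured compounds named here, the single measured step, a 1.5-fold lower number from compound 1 to compound 2 (0.17 log units; within the scatter), shows that the two numbers cannot be told apart. Compound 2 therefore holds the lowest of the two values, but only by a margin that means nothing.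

Compound 3 `O=C(/C=C/c1cc2ccccc2[nH]c1=O)c1ccc(Cl)cc1` has not yet been measured. It differs from compound 2 by chloro in place of hydroxy on an aromatic carbon, that is, on the aromatic carbon that sits para to a large group, a 4-hydroxyphenyl becomes a 4-chlorophenyl. Going by the values given here, no measured step exchanges hydroxy for chloro. Among the compounds with values here, the only step available, a 1.5-fold lower number from compound 1 to compound 2 (0.17 log units; within the scatter), alters the same position and stayed within the scatter, so it offers no direction for the present change and no direct guide to its size.

On that basis compound 3 is expected to stay close to compound 2, with a 1.1-fold higher number from compound 2 to compound 3 (0.03 log units; within the scatter) as the estimated step, and an estimated value of 5500 nM within a range from 2000 nM to 15000 nM.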

Compound 3, concentration for 50% growth inhibition: 17700 nM
The estimate for compound 3 lay 3.2-fold (0.51 log units) below the measured number; the measured number lies above the stated range.
By their numbers in this assay, from the lowest: compounds 2 and 1 (each within the scatter of the next); then compound 3.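

The aromatic carbon para to a large group had shown no readable response while only hydroxy and methoxy were compared, but in this assay chloro in place of hydroxy gives a 3.5-fold higher number from compound 2 to compound 3 (0.54 log units; beyond the scatter) as a modest step beyond the scatter. Chloro in place of methoxy points the same way, with a 2.3-fold higher number from compound 1 to compound 3 (0.37 log units; beyond the scatter) also modest and beyond the scatter. Among these three compounds, the two groups carrying oxygen therefore cannot be told apart, while the chloro compound 3 stands apart with the weakest inhibition of growth, so this position is not indifferent to what sits on it. No accompanying measurement offers an explanation for this shift.

Three compounds cannot show whether the weaker inhibition belongs to chloro alone or would also appear with fluoro, bromo or methyl at this place. On these data alone, it also remains open whether an amine, a carboxylic acid or a longer alkoxy chain would stay with hydroxy and methoxy or move with chloro.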